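Aryl exchange from compound 3 to compound 4

The source may report more compounds than this note shows. Statements on the series, on what has been measured and on what is new or still open speak of the compounds shown alone.

In a toxicity assay on WI-38 cells (Homo sapiens) for inhibition, read by MTT assay, with a stated time of 48 h (on this read-out lower numbers stand for stronger inhibition and higher numbers for weaker inhibition), compound 1 `Cc1ccc(/C=C2\SC(=O)N(CCNC(=O)Nc3c(C)n(C)n(-c4ccccc4)c3=O)C2=O)cc1` gives 48100 nM, compound 2 `Cc1c(NC(=O)NCCN2C(=O)S/C(=C\c3ccc([N+](=O)[O-])cc3)C2=O)c(=O)n(-c2ccccc2)n1C` gives 76400 nM and compound 3 `Cc1c(NC(=O)CN2C(=O)S/C(=C\c3ccc([N+](=O)[O-])cc3)C2=O)c(=O)n(-c2ccccc2)n1C` gives 43800 nM. Compound 3 has the lowest number of the three but lies within the scatter of both other compounds, so the three values do not separate.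

Compound 4 `Cc1cc(C)c(/C=C2\SC(=O)N(CC(=O)Nc3c(C)n(C)n(-c4ccccc4)c3=O)C2=O)c(C)c1` has not been measured. Its structural change is 2,4,6-trimethylphenyl in place of 4-nitrophenyl on a double-bonded chain carbon bound to a double-bonded ring carbon, with 2,4,6-trimethylphenyl in place of 4-nitrophenyl on a double-bonded chain carbon bound to a double-bonded ring carbon.

For the measured compounds named here, only one measured step bears on this change: a 1.6-fold higher number from compound 1 to compound 2 (0.20 log units; within the scatter), which places nitro where methyl stood on an aromatic carbon and stays within the scatter. Going by the values given here, that pair carries a different chain from compound 3, and no measured compound carries 2,4,6-trimethylphenyl, so the support is limited. No step beyond the scatter is therefore expected in this assay. The expected outcome is a 1.1-fold lower number from compound 3 to compound 4 (0.04 log units; within the scatter).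

For compound 4 the estimated value is 40000 nM, with an expected range of 18000 nM to 85000 nM.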

Compound 4, half-maximal inhibitory concentration: 39100 nM
Compound 4: the middle estimate sits 1.0-fold (0.01 log units) above what was measured; the measured number falls inside the stated range.
By their numbers in this assay, from the lowest: compounds 4, 3, 1 and 2 (each within the scatter of the next).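

In this assay, exchanging 4-nitrophenyl for 2,4,6-trimethylphenyl on a double-bonded chain carbon bound to a double-bonded ring carbon gives a 1.1-fold lower number from compound 3 to compound 4 (0.05 log units; within the scatter). For the compounds shown here, this is the first direct read of an aryl exchange at this place on this chain: a group with 2 hydrogen-bond acceptors gives way to one with 0, and the numbers do not separate. No supporting measurement speaks to what lies behind this flat result.

On these data alone, whether an aryl group carrying an amine or a carboxylic acid, or a non-aromatic group such as cyclohexyl, would move the number beyond the scatter at this position remains open. The compounds shown also leave open whether this flat response holds on a longer chain, and nothing here speaks to any read-out other than this assay.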